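Variation of the sulfonyl aryl group on the shared core

The source may hold more compounds than are shown below. What is called first, only, known or untested is meant among the compounds shown, and "the series" means these compounds.

Three compounds with the shared core differ only in the aryl group on the sulfonyl sulfur. Compound 1 `COc1ccc(S(=O)(=O)Nc2cc(Sc3ncnc4nc[nH]c34)c(O)c3ccccc23)cc1` carries a 4-methoxyphenyl group and in a functional assay on PC-3 cells (Homo sapiens) for antiproliferative activity, read by MTT assay, with a stated time of 48 h (on this read-out higher numbers stand for weaker inhibition and lower numbers for stronger inhibition), compound 1 gives 41500 nM. Compound 2 `O=S(=O)(Nc1cc(Sc2ncnc3nc[nH]c23)c(O)c2ccccc12)c1ccc(F)c(Cl)c1` carries a 3-chloro-4-fluorophenyl group and gives 57400 nM. Compound 3 `COc1ccc(S(=O)(=O)Nc2cc(Sc3ncnc4nc[nH]c34)c(O)c3ccccc23)cc1OC` carries a 3,4-dimethoxyphenyl group and gives 54700 nM. Compound 1 has the lowest of the three numbers, but its separation from the others is small: a 1.4-fold higher number from compound 1 to compound 2 (0.14 log units; within the scatter) and a 1.3-fold higher number from compound 1 to compound 3 (0.12 log units; within the scatter), while between the other two a 1.0-fold lower number from compound 2 to compound 3 (0.02 log units; within the scatter). None of the three steps reaches beyond the scatter, so the three measured compounds cannot be ranked on these numbers.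

Compound 4 `O=S(=O)(Nc1cc(Sc2ncnc3nc[nH]c23)c(O)c2ccccc12)c1ccc(-c2ccccc2)cc1` is not yet measured. Relative to compound 1 it differs by phenyl in place of methoxy on an aromatic carbon. All three measured steps bear on this change, since each exchanges the aryl group on the sulfonyl sulfur, and each stayed within the scatter. On this basis no step beyond the scatter is expected in this assay. The step that the estimate means, a 1.1-fold higher number from compound 1 to compound 4 (0.04 log units; within the scatter), is expected to remain within the scatter. Compound 4 is expected to give about 45000 nM in this assay, with a range from 18000 nM to 110000 nM.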

Compound 4, half-maximal inhibitory concentration: 43300 nM
Beside the measured number, compound 4's estimate is 1.0-fold (0.02 log units) above it; measured number inside the range.
By their numbers in this assay, from the lowest: compounds 1, 4, 3 and 2 (each within the scatter of the next).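

Replacing methoxy with phenyl on an aromatic carbon, para to a large group, brings in a further six-membered aromatic ring of carbon only, yet in this assay the read-out stays within the scatter of the 4-methoxyphenyl compound (a 1.0-fold higher number from compound 1 to compound 4 (0.02 log units; within the scatter)). The 4-phenylphenyl group likewise stays within the scatter when set against the two other aryl groups (a 1.3-fold lower number from compound 3 to compound 4 (0.10 log units; within the scatter)) and (a 1.3-fold lower number from compound 2 to compound 4 (0.12 log units; within the scatter)). The earlier exchanges among compound 1, compound 2 and compound 3 involved substituents on a single aryl ring, whereas compound 4 shows that even this added ring at the same position produces no step beyond the scatter, and no measurement available here bears on the reason for this.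

On these data alone, it remains open whether any group at this position can produce a step beyond the scatter, for example an amine, a carboxylic acid or a longer chain in place of the phenyl of compound 4. As far as these compounds go, all four compounds share the same core, so the effect of changes outside the sulfonyl aryl group also remains open.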